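A few compounds are considered here, and "the series" means these few. Any claim that something is new, unique, unknown or untested is made for them only; others in the source may bear on it.

Measured so far, in an assay on HEK293 cells for positive allosteric modulation of metabotropic glutamate receptor 5 (Homo sapiens), read by FLIPR, with a stated time of 1 h; a higher number here means that more compound is needed for the effect, a lower number that less compound is needed:
Compound 1 `CN1CCc2nc(C#Cc3cccc(F)c3)sc2C1` gives > 10000 nM, a limit of the assay.
Compound 2 `Fc1cccc(C#Cc2nc3c(s2)CN(C2CCOC2)CC3)c1` gives > 10000 nM, also a limit.
Compound 3 `O=C(C1CCC1)N1CCc2nc(C#Cc3ccccc3)sc2C1` gives > 10000 nM, again a limit.

Compound 3 therefore stands only at the limit of > 10000 nM in this assay, at which 3 of the 3 values shown sit, with no number of its own. Compound 4 `Cc1cccc(C(=O)N2CCc3nc(C#Cc4ccccc4)sc3C2)n1` differs from it in one place: 6-methylpyridin-2-yl in place of cyclobutyl on a carbonyl carbon. Going by the values given here, no measured step touches the amide part of the shared core; the single step measured, a step that the two limits leave unreadable from compound 1 to compound 2, concerns the amine nitrogen and its size stays hidden. The data thus give no guide to the direction or size of the change to expect in this assay. The estimate for compound 4 is 3000 nM, with a range from 400 nM to 20000 nM. That means an expected step of an at least 3.3-fold lower number from compound 3 to compound 4 (0.52 log units; beyond the scatter).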

Compound 4, half-maximal effective concentration: 160 nM
Compound 4: the middle estimate sits 19-fold (1.27 log units) above what was measured; measured number outside the range, below it.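

In this assay, the group on the carbonyl carbon of the shared core proves to be a place where a single change can matter: 6-methylpyridin-2-yl in place of cyclobutyl gives an at least 62-fold lower number from compound 3 to compound 4 (1.79 log units; beyond the scatter). Compound 4 is also the only compound shown with a number of its own, while the others stay at a limit: the limit of > 10000 nM in this assay, at which 3 of the 4 values shown sit.

The compounds shown leave open which part of the entering group carries this step: the ring nitrogen, the methyl or the aromatic ring itself. A phenyl or an unsubstituted pyridin-2-yl on the same carbonyl carbon would help separate these.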